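Adding a hydroxymethyl where every value is a limit

The source may report more compounds than this note shows. Statements on the series, on what has been measured and on what is new or still open speak of the compounds shown alone.

Of the compounds shown here, three have been tested in an ADME assay on MCF7 cells (Homo sapiens) for cytotoxicity, read by luminescence and ATP content, with a stated time of 48 h; a lower number here means a stronger inhibitor, a higher number a weaker inhibitor. Compound 1 `O=C1OCC(c2ccc(C(F)(F)F)cc2)=C1c1c[nH]c2ccccc12` gives > 40000 nM, which is a limit rather than a number. Compound 2 `O=C1OCC(c2ccc(C(F)(F)F)cc2)=C1c1ccncc1` gives > 40000 nM, again a limit. Compound 3 `COc1ccc(C2=C(c3ccc(OC)c(OC)c3)C(CO)OC2=O)cc1` gives > 40000 nM, once more a limit. Compound 3 therefore stands exactly where all the values shown stand, namely at the limit of > 40000 nM in this assay, at which 3 of the 3 values shown sit. Compound 4 `COc1ccc(C2=C(c3ccc(OC)c(OC)c3)C(CO)(CO)OC2=O)cc1` differs from compound 3 by hydroxymethyl in place of hydrogen on a saturated ring carbon, in words hydroxymethyl in place of hydrogen on a saturated ring carbon. Among the measured compounds shown here, no step between two measured compounds is available, so there is no measured guide to the size of this change. The step of a number no higher from compound 3 to compound 4 (the limit leaves the size open) is expected to stay within the scatter. Compound 4 is estimated at 40000 nM, within 20000 nM to 80000 nM, most probably again a limit.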

Compound 4, half-maximal inhibitory concentration: > 40000 nM
Compound 4 was reported as a limit (the forecaster's own chance of this, stated with the estimate: 85%); the middle value sits exactly at the limit.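

Compound 3 and compound 4 both sit at a limit, so no step between them can be read: the limit of > 40000 nM in this assay, at which 4 of the 4 values shown sit.

The compounds shown leave open whether hydroxymethyl in place of hydrogen on a saturated ring carbon changes inhibition at all.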